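Compound 3 to compound 4: a smaller amine substituent

A few compounds are considered here, and "the series" means these few. Any claim that something is new, unique, unknown or untested is made for them only; others in the source may bear on it.

In a functional assay on the whole organism with Mus musculus as the target (a higher number here means that more compound is needed for the effect, a lower number that less compound is needed), compound 1 (`CNC(=O)[C@@H](C)NCc1ccc(OCc2ccccc2)cc1`) gives 40.5 mg/kg, compound 2 (`CNC(=O)[C@H](CO)NCc1ccc(OCc2ccccc2)cc1`) gives 15 mg/kg and compound 3 (`CNC(=O)[C@H](NCc1ccc(OCc2ccccc2)cc1)C(C)C`) gives 112 mg/kg. Compound 3 therefore holds the highest number of the three, and it lies beyond the scatter from both others: a 2.8-fold higher number from compound 1 to compound 3 (0.44 log units; beyond the scatter), and a 7.5-fold higher number from compound 2 to compound 3 (0.87 log units; beyond the scatter).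

Compound 4 (`CC[C@H](NCc1ccc(OCc2ccccc2)cc1)C(N)=O`) is still to be measured. The change is 1-carbamoylpropyl in place of 2-methyl-1-(methylcarbamoyl)propyl on an amine nitrogen.

The closest guide is the modest step of a 2.8-fold higher number from compound 1 to compound 3 (0.44 log units; beyond the scatter), where isopropyl replaces methyl on a saturated chain carbon. Read in reverse, it suggests that a smaller group than the one in compound 3 should bring the number down. The step of a 2.7-fold lower number from compound 1 to compound 2 (0.43 log units; beyond the scatter) involves a hydroxy-bearing group that compound 4 does not have, so it offers little guidance. Within the data shown here, no measured step covers the change from methylcarbamoyl to carbamoyl, which leaves the range wide.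

A modest drop is expected, with the estimated step being a 2.2-fold lower number from compound 3 to compound 4 (0.35 log units; beyond the scatter). The estimate for compound 4 is 50 mg/kg, with an expected range of 18 mg/kg to 130 mg/kg.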

Compound 4, dose for half-maximal effect: 119 mg/kg
For compound 4 the middle estimate is 2.4-fold (0.38 log units) below the measured one; the range from low to high includes it.
By their numbers in this assay, from the lowest: compound 2; then compound 1; then compounds 3 and 4 (each within the scatter of the next).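

In this assay, 1-carbamoylpropyl in place of 2-methyl-1-(methylcarbamoyl)propyl on the amine nitrogen gives a 1.1-fold higher number from compound 3 to compound 4 (0.03 log units; within the scatter), so this smaller substituent does not separate compound 4 from compound 3, and the lower number suggested by the step between the methyl and isopropyl compounds does not appear here. Compound 4 instead stays with compound 3 above the other two compounds, with a 2.9-fold higher number from compound 1 to compound 4 (0.47 log units; beyond the scatter) and a 7.9-fold higher number from compound 2 to compound 4 (0.90 log units; beyond the scatter), so among the four substituents at this position, the lower numbers remain with 1-(methylcarbamoyl)ethyl and 2-hydroxy-1-(methylcarbamoyl)ethyl. No measured information accounts for this result.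

This change alters the side chain and the amide together, so the compounds shown do not tell what each alteration does alone, or whether the two offset each other. Also open, going by these compounds, is how a carboxylic acid in place of the carbamoyl group, or an amine on the side chain, would read in this assay.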